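The source may hold more compounds than are shown below. What is called first, only, known or untested is meant among the compounds shown, and "the series" means these compounds.

Measured in a functional assay on HeLa cells (Homo sapiens) for antiproliferative activity, read by MTT assay, with a stated time of 72 h; on this read-out lower numbers stand for stronger inhibition and higher numbers for weaker inhibition:
- compound 1 `COc1cc(C(=O)c2sc3ccccc3c2-c2ccc(C)cc2)cc(OC)c1OC`: 3700 nM
- compound 2 `COc1ccc(OC)c(-c2c(C(=O)c3cc(OC)c(OC)c(OC)c3)sc3ccccc23)c1`: 10000 nM
- compound 3 `COc1ccc(-c2c(C(=O)c3cc(OC)c(OC)c(OC)c3)sc3ccccc23)cc1C`: 10000 nM

Compound 3, at 10000 nM, is level with compound 2, and together they hold the highest of the three numbers. The lowest number belongs to compound 1, at 3700 nM.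

The next molecule, compound 4 `COc1cc(C(=O)c2sc3ccccc3c2Nc2ccccc2)cc(OC)c1OC`, has not been measured yet. It carries anilino in place of 4-methoxy-3-methylphenyl on an aromatic carbon, two ring bonds from the ring sulfur: anilino in place of 4-methoxy-3-methylphenyl on an aromatic carbon.

Within the data shown here, no measured step brings in anilino, so the evidence is indirect. Three steps swap the group on this same carbon. Two are modest: a 2.7-fold higher number from compound 1 to compound 2 (0.43 log units; beyond the scatter) and a 2.7-fold higher number from compound 1 to compound 3 (0.43 log units; beyond the scatter). The third is no change at the digits printed from compound 2 to compound 3 (within the scatter), which lies within the scatter. Swaps here have therefore moved the number only slightly so far. The ring of anilino has no methoxy group, as in compound 1 at 3700 nM, which points weakly towards a lower number, although the new nitrogen has no precedent among these compounds.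

In this assay the expected change is small and downward, with an estimated 2.0-fold lower number from compound 3 to compound 4 (0.30 log units; within the scatter). The estimate for compound 4 is 5000 nM, with an expected range of 1200 nM to 15000 nM.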

Compound 4, half-maximal inhibitory concentration: 2700 nM
Compound 4: the middle estimate sits 1.9-fold (0.27 log units) above what was measured; low and high end bracket the measured number.
By their numbers in this assay, from the lowest: compounds 4 and 1 (each within the scatter of the next); then compounds 2 and 3 (each within the scatter of the next).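

In this assay, this carbon of the shared core accepts a ring attached through nitrogen: anilino, which brings a hydrogen-bond donor absent from the group it replaces, gives a 3.7-fold lower number from compound 3 to compound 4 (0.57 log units; beyond the scatter) and, against the other dimethoxy-free comparison's opposite case, a 3.7-fold lower number from compound 2 to compound 4 (0.57 log units; beyond the scatter), both beyond the scatter. Set against 4-methylphenyl, the same group gives a 1.4-fold lower number from compound 1 to compound 4 (0.14 log units; within the scatter) and stays within the scatter, so a directly attached ring and a nitrogen-linked ring cannot be told apart in this pair. Among these four compounds, the two whose ring at this carbon has no methoxy group, compound 1 and compound 4, both show lower numbers than compound 2 and compound 3, and no measurement shown here explains this pattern.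

Compound 4 changes both the link and the ring's substituents at once, which leaves open whether the nitrogen or the unsubstituted ring accounts for its step from compound 3. A 4-methoxy-3-methylanilino group at this carbon would separate those two changes, while a benzylamino group, with its longer chain, would test how far the ring can sit from the core.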